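The source may report more compounds than this note shows. Statements on the series, on what has been measured and on what is new or still open speak of the compounds shown alone.

In a functional assay on HCT-116 cells (Homo sapiens) for cytotoxicity, read by MTT assay, with a stated time of 48 h (on this read-out higher numbers stand for weaker inhibition and lower numbers for stronger inhibition), three compounds have been measured:

Compound 1, `O=C(Nc1ccc(Br)cc1)c1cn(-c2ccccc2)nc1-c1ccccc1`, gives 4470 nM.
Compound 2, `Cc1ccc(-c2nn(-c3ccccc3)cc2C(=O)Nc2ccccc2)cc1`, gives 2360 nM.
Compound 3, `COc1ccc(NC(=O)c2cn(-c3ccccc3)nc2-c2ccc(C)cc2)cc1`, gives 1450 nM.

Compound 2 and compound 3 share a core and differ in one place: methoxy in place of hydrogen on an aromatic carbon. This change gave a 1.6-fold lower number from compound 2 to compound 3 (0.21 log units; within the scatter). Compound 1 carries a different core; the difference between the two cores is not broken down here. Its number and that of compound 2 lie within the usual scatter of each other, so nothing can be said about which of the two is stronger, while compound 3 stands at a lower number than compound 1 by more than the scatter.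

Compound 4, `COc1ccc(-c2nn(-c3ccccc3)cc2C(=O)Nc2ccc(Br)cc2)cc1`, has not yet been measured. It differs from compound 1 in the same way that compound 3 differs from compound 2: methoxy in place of hydrogen on an aromatic carbon. Within the data shown here, because the only measured example of this change gave a 1.6-fold lower number from compound 2 to compound 3 (0.21 log units; within the scatter), a step of about the same size is expected in this assay , namely a 1.6-fold lower number from compound 1 to compound 4 (0.20 log units; within the scatter). On that basis compound 4 is estimated to give 2800 nM, most likely between 1400 nM and 5600 nM.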

Compound 4, half-maximal inhibitory concentration: 5870 nM
Beside the measured number, compound 4's estimate is 2.1-fold (0.32 log units) below it; measured number outside the range, above it.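

In this assay, the change from phenyl to 4-methoxyphenyl gave a 1.3-fold higher number from compound 1 to compound 4 (0.12 log units; within the scatter), so the two compounds cannot be ranked against each other. Set beside the earlier example, the new step has the opposite direction on paper, but the two steps do not truly differ: the same change on two cores in this assay, a 1.6-fold lower number (0.21 log units; within the scatter) from compound 2 to compound 3 and a 1.3-fold higher number (0.12 log units; within the scatter) from compound 1 to compound 4, 2.1-fold (0.33 log units) apart, within the scatter of two such steps. This fits a change that moves the number too little to detect on either core, but it does not show that the change has no effect at all, and with neither step beyond the scatter, it cannot show that a fixed step carries from one core to another.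

The compounds shown leave open whether a different group at the same place, such as an amine or a carboxylic acid, would move the number by more than the scatter. They also leave open whether methoxy would give a readable step on any further core in this series.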